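Swapping a Benzyl for a Urea on the Ring Nitrogen

This account rests on a few compounds, and the source may have more. Where it says the series, first, only, none or still open, it means among the compounds named here.

Compound 1 `NC(=O)c1c(NC(=O)c2ccccc2Cl)sc2c1CCNC2` — 45000 nM
Compound 2 `NC(=O)c1c(NC(=O)c2ccccc2Cl)sc2c1CCN(Cc1ccc([N+](=O)[O-])cc1)C2` — 46100 nM
Compound 3 `NC(=O)c1c(NC(=O)c2ccccc2Cl)sc2c1CCN(Cc1ccc(Cl)cc1Cl)C2` — 21100 nM

All three share one core; they differ only in what sits on the amine nitrogen in the ring. In a functional assay on HeLa cells (Homo sapiens) for antiproliferative activity, with a stated time of 24 h (on this read-out higher numbers stand for weaker inhibition and lower numbers for stronger inhibition), compound 3 has the lowest number of the three, yet the gaps are modest: a 2.1-fold lower number from compound 1 to compound 3 (0.33 log units; beyond the scatter) and a 2.2-fold lower number from compound 2 to compound 3 (0.34 log units; beyond the scatter). Compound 1 and compound 2 sit within the scatter of each other, as a 1.0-fold higher number from compound 1 to compound 2 (0.01 log units; within the scatter) shows.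

Compound 4 `NC(=O)c1c(NC(=O)c2ccccc2Cl)sc2c1CCN(C(=O)Nc1ccccc1Cl)C2` has not yet been measured. It differs from compound 3 by (2-chlorophenyl)carbamoyl in place of 2,4-dichlorobenzyl on an amine nitrogen in a ring. Among the measured compounds shown here, no measured step involves a carbamoyl at this position, so the two steps toward compound 3 are the only guide; they show that changing this substituent moved this assay only modestly. A modest step back toward the numbers of compound 1 and compound 2 is therefore expected for compound 4, as a 1.7-fold higher number from compound 3 to compound 4 (0.22 log units; within the scatter). Compound 4 is estimated at 35000 nM, with a range from 12000 nM to 100000 nM.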

Compound 4, half-maximal inhibitory concentration: 45400 nM
Estimate against measurement, compound 4: 1.3-fold (0.11 log units) below; the measured number falls inside the stated range.
By their numbers in this assay, from the lowest: compound 3; then compounds 1, 4 and 2 (each within the scatter of the next).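

In this assay, (2-chlorophenyl)carbamoyl on the amine nitrogen in the ring does not match 2,4-dichlorobenzyl (a 2.2-fold higher number from compound 3 to compound 4 (0.33 log units; beyond the scatter)). The urea instead sits level with the bare hydrogen (a 1.0-fold higher number from compound 1 to compound 4 (0.00 log units; within the scatter)) and with 4-nitrobenzyl (a 1.0-fold lower number from compound 2 to compound 4 (0.01 log units; within the scatter)), so among these four, compound 3 alone stands apart, and only by modest steps. Nothing measured here shows which difference between the groups, including the hydrogen-bond donor and acceptor that enter with the urea, accounts for this.

Still open, as far as these compounds go, is whether a urea carrying a 2,4-dichlorophenyl ring would behave like compound 3 or like compound 4. Also open, from the compounds shown here alone, is how a small acetyl group, or a longer chain ending in an amine, would behave on this nitrogen.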